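The source may hold more compounds than are shown below. What is called first, only, known or untested is meant among the compounds shown, and "the series" means these compounds.

In a functional assay on MCF7 cells (Homo sapiens) for antiproliferative activity, read by sulforhodamine B assay, with a stated time of 48 h (a higher number here means a weaker inhibitor, a lower number a stronger inhibitor), the measured compounds are:
- compound 1 `CCc1ccccc1NS(=O)(=O)c1ccc(N2CCNC2=O)cc1` at 350 nM
- compound 2 `O=C1NCCN1c1ccc(S(=O)(=O)Nc2ccc(F)cc2)cc1` at 690 nM
- compound 3 `O=C1NCCN1c1ccc(S(=O)(=O)Nc2ccc(F)c(F)c2)cc1` at 620 nM

Compound 2 cannot be told apart from the other two, with steps of a 2.0-fold higher number from compound 1 to compound 2 (0.29 log units; within the scatter) and a 1.1-fold lower number from compound 2 to compound 3 (0.05 log units; within the scatter).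

Compound 4 `O=C1NCCN1c1ccc(S(=O)(=O)Nc2ccc(OC(F)F)cc2)cc1` carries difluoromethoxy in place of fluoro on an aromatic carbon, para to a large group (difluoromethoxy in place of fluoro on an aromatic carbon). Among the measured compounds shown here, no measured step makes this exchange. The steps that do alter this aromatic group, a 1.1-fold lower number from compound 2 to compound 3 (0.05 log units; within the scatter) and a 1.8-fold higher number from compound 1 to compound 3 (0.25 log units; within the scatter), all stayed within the scatter. No step beyond the scatter is therefore expected in this assay, in either direction. The expected step is a 1.2-fold lower number from compound 2 to compound 4 (0.06 log units; within the scatter). For compound 4 the estimate is 600 nM, with an expected range from 270 nM to 1300 nM.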

Compound 4, half-maximal inhibitory concentration: 760 nM
The estimate for compound 4 lay 1.3-fold (0.10 log units) below the measured number; measured number inside the range.
By their numbers in this assay, from the lowest: compounds 1, 3, 2 and 4 (each within the scatter of the next, the first and the last beyond it).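

In this assay, putting difluoromethoxy in place of fluoro, para to a large group, gives a 1.1-fold higher number from compound 2 to compound 4 (0.04 log units; within the scatter): a group of 4 heavy atoms with a hydrogen-bond acceptor replaces a single fluorine with no step beyond the scatter. The earlier steps shown here covered only an added fluoro on this aromatic ring and exchanges with 2-ethylphenyl, so they did not test a larger group at this place. Nothing measured here explains this tolerance.

From the compounds shown here alone, whether an amine or a carboxylic acid at this place would also stay within the scatter remains open.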